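Half-life notes: methyl in place of carboxy

The compounds below may be only part of what the source reports. "The series", "measured", "known", "first", "only" and "open" are said of these compounds alone.

compound 1 `CO/N=C(\C(=O)N[C@@H]1C(=O)N2C(C(=O)[O-])=C(C[n+]3cccc4occc43)CS[C@H]12)c1csc(N)n1`: 1.67 h
compound 2 `CO/N=C(\C(=O)N[C@@H]1C(=O)N2C(C(=O)[O-])=C(C[n+]3ccc4sc(C(=O)O)cc4c3)CS[C@H]12)c1csc(N)n1`: 1.5 h

Among the measured compounds shown here, in an in vivo ADME assay on the whole organism for metabolic stability, with Canis familiaris (Canis lupus familiaris) as the target, at a dose of 60 mg/kg (a lower number here means that the compound disappears faster, a higher number that the compound lasts longer), compound 2 sits within the scatter of compound 1, the only other measured compound. Compound 3 `CO/N=C(\C(=O)N[C@@H]1C(=O)N2C(C(=O)[O-])=C(C[n+]3ccc4sc(C)cc4c3)CS[C@H]12)c1csc(N)n1` differs from compound 2 as follows: methyl in place of carboxy on an aromatic carbon. For the measured compounds named here, one measured step bears on this, the exchange of the whole group in a 1.1-fold lower number from compound 1 to compound 2 (0.05 log units; within the scatter), which stayed within the scatter. Going by the values given here, no measured step isolates the carboxy. An estimated 1.1-fold higher number from compound 2 to compound 3 (0.03 log units; within the scatter) is therefore expected, with no change beyond the scatter. In this assay, the estimate for compound 3 is 1.6 h, with an expected range of 1 h to 2.5 h.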

Compound 3, half-life: 1.67 h
Compound 3: the middle estimate sits 1.0-fold (0.02 log units) below what was measured; measured number inside the range.
By their numbers in this assay, from the lowest: compounds 2, 1 and 3 (each within the scatter of the next).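

In this assay, methyl in place of carboxy on this aromatic carbon, next to the ring sulfur, gives a 1.1-fold higher number from compound 2 to compound 3 (0.05 log units; within the scatter) and is the first change shown that isolates the carboxy, whose loss leaves the half-life unmoved. The exchange of the whole group on the saturated chain carbon likewise gives no change at the digits printed from compound 1 to compound 3 (within the scatter) and so leaves compounds 1 and 3 indistinguishable here. Nothing available explains why the half-life stays flat across these changes.

Open, from the compounds shown here alone, is whether an amine or a longer chain on this aromatic carbon would also stay within the scatter. Also open, going by these compounds, is whether the same holds at other doses.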